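Removing a Methoxy From Nitrofuran Amides on a Fused Core

The source may report more compounds than this note shows. Statements on the series, on what has been measured and on what is new or still open speak of the compounds shown alone.

Of the compounds shown here, three have so far been tested in a functional assay on MGC-803 cells (Homo sapiens) for antiproliferative activity, read by CCK-8 assay, with a stated time of 72 h; a higher number here means a weaker inhibitor, a lower number a stronger inhibitor. Compound 1 `COc1ccn2c(-c3ccc(NC(=O)c4ccc([N+](=O)[O-])o4)cc3C)cnc2c1` gives 1030 nM in this assay. Compound 2 `COc1ccn2c(-c3ccc(NC(=O)c4ccc([N+](=O)[O-])o4)c(C)c3)cnc2c1` has the same atoms as compound 1, joined differently; the difference between the two cores is not broken down here. In this assay compound 2 gives 1380 nM. Compound 3 `Cc1cc(-c2cnc3ccccn23)ccc1NC(=O)c1ccc([N+](=O)[O-])o1` differs from compound 2 in one place: hydrogen in place of methoxy on an aromatic carbon. In this assay compound 3 gives 1830 nM, so that this change gave a 1.3-fold higher number from compound 2 to compound 3 (0.12 log units; within the scatter). All three values lie within the usual scatter of one another.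

Compound 4 `Cc1cc(NC(=O)c2ccc([N+](=O)[O-])o2)ccc1-c1cnc2ccccn12` has not yet been measured. It differs from compound 1 by hydrogen in place of methoxy on an aromatic carbon. Among the compounds with values here, the place is described in exactly the same words for both pairs, so this is the same change as the one between compound 2 and compound 3, made this time on the core of compound 1 rather than that of compound 2.

The expectation for compound 4 rests on a single measured instance of this change, the step of a 1.3-fold higher number from compound 2 to compound 3 (0.12 log units; within the scatter), which stayed within the scatter. For compound 4 the expected result in this assay is therefore 1350 nM, with a likely range from 700 nM to 2600 nM. For compound 4 this estimate means a step of a 1.3-fold higher number from compound 1 to compound 4 (0.12 log units; within the scatter).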

Compound 4, half-maximal inhibitory concentration: 900 nM
Estimate against measurement, compound 4: 1.5-fold (0.18 log units) above; the measured number falls inside the stated range.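

In this assay, putting hydrogen in place of methoxy on the core of compound 1 gave a 1.1-fold lower number from compound 1 to compound 4 (0.06 log units; within the scatter) and so produced no shift that can be told apart from ordinary repeat-to-repeat variation. Set beside the earlier case, the two results agree as closely as measurements of this kind allow: the same change on two cores in this assay, a 1.3-fold higher number (0.12 log units; within the scatter) from compound 2 to compound 3 and a 1.1-fold lower number (0.06 log units; within the scatter) from compound 1 to compound 4, 1.5-fold (0.18 log units) apart, within the scatter of two such steps. This shows that, in these two pairs, the methoxy can be removed from either core with no measurable effect on the read-out and that the result on one core matched the result on the other, but it does not show that the methoxy is without any effect, since a small real effect could be hidden in the scatter, and two pairs cannot establish a rule for the whole series.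

Only methoxy and hydrogen appear at this aromatic carbon among the compounds shown, so it remains open whether an amine, a carboxylic acid or a longer chain such as butoxy would also leave the read-out unchanged. On these data alone, it also remains open whether the same would hold on a core other than these two, or in a different cell line.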